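Cyclohexyl for cyclopropyl on the amide-type nitrogen

This account rests on a few compounds, and the source may have more. Where it says the series, first, only, none or still open, it means among the compounds named here.

Of the compounds shown here, three with a shared core have been read in a functional assay on HepG2 cells (Homo sapiens) for antiproliferative activity, read by MTT assay, with a stated time of 72 h; on this read-out higher numbers stand for weaker inhibition and lower numbers for stronger inhibition. Compound 1 `COc1cccc(N2C(=O)COc3ccc(-c4cccc(NS(=O)(=O)c5ccc(F)cc5)c4)cc32)c1` gives > 40000 nM, which is a limit. Within the data shown here, compound 2 `O=C1COc2ccc(-c3cccc(NS(=O)(=O)c4ccc(F)cc4)c3)cc2N1c1ccc(Cl)cc1` gives 27800 nM, the only actual number so far. Compound 3 `O=C1COc2ccc(-c3cccc(NS(=O)(=O)c4ccc(F)cc4)c3)cc2N1C1CC1` gives > 40000 nM, which is also a limit, so it stands without a number. The series is thus dominated by the limit of > 40000 nM in this assay, at which 2 of the 3 values shown sit.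

Compound 4 `O=C1COc2ccc(-c3cccc(NS(=O)(=O)c4ccc(F)cc4)c3)cc2N1C1CCCCC1` carries one change: cyclohexyl in place of cyclopropyl on an amide-type nitrogen in a ring. The measured steps at this nitrogen are an at least 1.4-fold lower number from compound 1 to compound 2 (0.15 log units; that floor lies within the scatter), an at least 1.4-fold higher number from compound 2 to compound 3 (0.15 log units; that floor lies within the scatter) and a step that the two limits leave unreadable from compound 1 to compound 3. None of them is shown to exceed the scatter, and none compares two non-aromatic rings of carbon only. Given an at least 1.4-fold higher number from compound 2 to compound 3 (0.15 log units; that floor lies within the scatter), no step beyond the scatter is expected in this assay. The estimated step is an at least 1.0-fold lower number from compound 3 to compound 4 (0.02 log units; that floor lies within the scatter). The estimate for compound 4 is 38000 nM, with an expected range of 18000 nM to 80000 nM.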

Compound 4, half-maximal inhibitory concentration: 35900 nM
Compound 4: the middle estimate sits 1.1-fold (0.02 log units) above what was measured; the measured number falls inside the stated range.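

In this assay, among these compounds, compound 4 is the first with a non-aromatic ring of carbon only on the amide-type nitrogen to give an actual number, so it can be read against the 4-chlorophenyl group: a 1.3-fold higher number from compound 2 to compound 4 (0.11 log units; within the scatter). The two other comparisons, an at least 1.1-fold lower number from compound 3 to compound 4 (0.04 log units; that floor lies within the scatter) and an at least 1.1-fold lower number from compound 1 to compound 4 (0.04 log units; that floor lies within the scatter), show neither cyclohexyl for cyclopropyl nor cyclohexyl for 3-methoxyphenyl moving the read-out beyond the scatter. This position has so far given no step shown to exceed the scatter, and the values stay crowded at the limit: the limit of > 40000 nM in this assay, at which 2 of the 4 values shown sit.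

As far as these compounds go, whether a carboxylic acid or an amine on a longer chain at this nitrogen would move the read-out beyond the scatter stays open. So does the outcome with a plain methyl group or the amide hydrogen at this place.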